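Swapping Ethylamino for Dipropylamino on a Shared Core

This account rests on a few compounds, and the source may have more. Where it says the series, first, only, none or still open, it means among the compounds named here.

Three measured compounds share one core and differ only in the group on one aromatic carbon. Compound 1 `C[C@H](Nc1nc(Cl)nc(NC(C)(C)C)n1)c1ccccc1` carries a (tert-butyl)amino group, compound 2 `CC(C)N(c1nc(Cl)nc(N[C@@H](C)c2ccccc2)n1)C(C)C` a diisopropylamino group, and compound 3 `CCNc1nc(Cl)nc(N[C@@H](C)c2ccccc2)n1` an ethylamino group. In an ADME assay on the whole organism for inhibition, with Echinochloa crus-galli var. formosensis as the target, with a stated time of 4 days (on this read-out higher numbers stand for weaker inhibition and lower numbers for stronger inhibition), compound 1 gives 7410 nM, compound 2 gives 110 nM, and compound 3 gives 30900 nM. Compound 3 therefore stands highest of the three numbers, so it is the weakest inhibitor of the set. Its nearest neighbour is compound 1, seen in the step of a 4.2-fold higher number from compound 1 to compound 3 (0.62 log units; beyond the scatter), and its furthest is compound 2, seen in the step of a 280-fold higher number from compound 2 to compound 3 (2.45 log units; beyond the scatter).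

Compound 4 `CCCN(CCC)c1nc(Cl)nc(N[C@@H](C)c2ccccc2)n1` has not been measured. It differs from compound 3 in one place: dipropylamino in place of ethylamino on an aromatic carbon. Within the data shown here, two steps bear on this change. The step of a 280-fold higher number from compound 2 to compound 3 (2.45 log units; beyond the scatter) shows how far a dialkylamino group sits below ethylamino, and the step of a 67-fold lower number from compound 1 to compound 2 (1.83 log units; beyond the scatter) shows the same dialkylamino group far below (tert-butyl)amino. Dipropylamino is also a dialkylamino group, though not identical to diisopropylamino, so a large step toward lower numbers is expected, with some caution about its exact size. Compound 4 is thus expected to give about 500 nM, within 100 nM to 3000 nM. The expected step is a 62-fold lower number from compound 3 to compound 4 (1.79 log units; beyond the scatter).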

Compound 4, half-maximal inhibitory concentration: 100 nM
For compound 4 the middle estimate is 5.0-fold (0.70 log units) above the measured one; measured number inside the range.
By their numbers in this assay, from the lowest: compounds 4 and 2 (each within the scatter of the next); then compound 1; then compound 3.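

Compound 4 shows that the large drop at this position does not belong to diisopropylamino alone: in this assay the change to dipropylamino gives a 310-fold lower number from compound 3 to compound 4 (2.49 log units; beyond the scatter) and so matches the size of the drop already seen with the other dialkylamino group. The two dialkylamino groups cannot be told apart here, as a 1.1-fold lower number from compound 2 to compound 4 (0.04 log units; within the scatter) shows, so the difference between two propyl chains and two isopropyl groups leaves no readable mark on this read-out. The comparison with the remaining monoalkylamino group points the same way, with a 74-fold lower number from compound 1 to compound 4 (1.87 log units; beyond the scatter) again a large step, so in these four compounds both groups with two chains on the nitrogen give lower numbers than both groups with one chain.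

Ethylamino to dipropylamino changes two things at once, from 3 heavy atoms to 7 and from 1 hydrogen-bond donor to 0, and these compounds cannot separate the two; propylamino, with one longer chain and its amine hydrogen kept, or diethylamino, with two shorter chains, would help to pull them apart. Nothing measured here gives a reason for these steps.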